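Fluoro for Methyl: Expected Efficacy of Compound 3

The source may report more compounds than this note shows. Statements on the series, on what has been measured and on what is new or still open speak of the compounds shown alone.

compound 1 `O=C(CN1CCC(c2cccc[n+]2[O-])CC1)Nc1cccc(Cl)c1`: 76%
compound 2 `Cc1ccc(C(=O)NCN2CCC(c3cccc[n+]3[O-])CC2)cc1C`: 65%

Of the compounds shown here, two have so far been measured in a functional assay on HEK293 cells for agonist activity at D(4) dopamine receptor (Homo sapiens), read by FLIPR; on this read-out higher numbers stand for larger maximal responses and lower numbers for smaller maximal responses. Compound 1 gives 76% there, and compound 2 gives 65%. Compound 2 thus stands lowest of the two numbers; its nearest neighbour is compound 1, whose number lies higher by a margin beyond the usual scatter. Among the measured compounds shown here, no pair of measured compounds differs in only one place, so nothing among the measured data shows how a single small change moves the read-out.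

Compound 3 `Cc1cc(C(=O)NCN2CCC(c3cccc[n+]3[O-])CC2)ccc1F` has not yet been measured in this assay. It differs from compound 2 in one place: fluoro in place of methyl on an aromatic carbon. The rest of the structure is shared between the two compounds. For the measured compounds named here, with no measured step of this kind to draw on, the expectation is a step of no size beyond the scatter, in either direction: the expected step in this assay is a number 3 percentage points lower from compound 2 to compound 3 (within the scatter). Compound 3 is accordingly estimated to reach 62% in this assay, with a range from 45% to 80%.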

Compound 3, largest response reached (reported as efficacy), in percent of the reference or control that the assay uses: 67%
Compound 3: middle estimate off by 5 percentage points, on the low side; measured number inside the range.
By their numbers in this assay, from the lowest: compounds 2, 3 and 1 (each within the scatter of the next, the first and the last beyond it).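

In this assay, among the compounds shown here, the change of 3,4-dimethylphenyl to 4-fluoro-3-methylphenyl gives a number 2 percentage points higher from compound 2 to compound 3 (within the scatter) and is the first single change that can be read on its own. The earlier compounds shown here could not show this, as no two of them differed in one place only. It shows that at this position on the aromatic ring, ortho to a methyl group and para to a large group, fluoro in place of methyl leaves the maximal response within the usual scatter, at least in this one pair. Nothing measured here offers an explanation for this result.

The compounds shown leave open whether other groups at the same position, such as methoxy, trifluoromethyl or an amine, would also keep the response where compound 2 and compound 3 stand. They also leave open whether the remaining methyl group could be exchanged for fluoro or for a longer chain with as small a step, since this single pair speaks only for the one position.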